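This account rests on a few compounds, and the source may have more. Where it says the series, first, only, none or still open, it means among the compounds named here.

In a functional assay on CCRF-CEM cells (Homo sapiens) for cytotoxicity, read by cell counting, with a stated time of 3 days (a higher number here means a weaker inhibitor, a lower number a stronger inhibitor), compound 3 `C=C(Br)C(=O)Nc1ccc(/C=C2\SC(=O)N(Cc3ccc(F)cc3)C2=O)cc1` gives 2400 nM, the second highest of the three numbers recorded so far. Compound 2 `C=C(Br)C(=O)Nc1ccc(/C=C2\SC(=O)N(C)C2=O)cc1` gives 360 nM, and compound 1 `Nc1ccc(/C=C2\SC(=O)N(Cc3cccc(F)c3)C2=O)cc1` gives 116000 nM. For the measured compounds named here, the only step measured between neighbours, a 6.7-fold higher number from compound 2 to compound 3 (0.82 log units; beyond the scatter), concerns the addition of the whole substituent and does not bear on the change now in question. Compound 4 `C=C(Br)C(=O)Nc1ccc(/C=C2\SC(=O)N(Cc3cccc(F)c3)C2=O)cc1` differs from compound 3 only in 3-fluorophenyl in place of 4-fluorophenyl on a saturated chain carbon bound to an amide-type nitrogen in a ring; the two have the same atoms, joined differently. Going by the values given here, no measured pair compares a 4-fluorophenyl with a 3-fluorophenyl, so no step beyond the scatter is expected in this assay. Compound 4 is therefore estimated at 2400 nM, with a range from 800 nM to 7000 nM, which is an expected step of no change at the digits printed from compound 3 to compound 4 (within the scatter).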

Compound 4, half-maximal inhibitory concentration: 3200 nM
Compound 4: middle estimate off by 1.3-fold (0.12 log units), on the low side; the measured number falls inside the stated range.
By their numbers in this assay, from the lowest: compound 2; then compounds 3 and 4 (each within the scatter of the next); then compound 1.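

In this assay the change from 4-fluorophenyl to 3-fluorophenyl gives a 1.3-fold higher number from compound 3 to compound 4 (0.12 log units; within the scatter) and so does not separate the two fluorine placements. Against hydrogen at this carbon, 3-fluorophenyl gives an 8.9-fold higher number from compound 2 to compound 4 (0.95 log units; beyond the scatter) in the same direction as the 4-fluorophenyl step. For the compounds shown here, with the 3-fluorobenzyl group held fixed, (1-bromoethenyl)carbonyl in place of hydrogen on a nitrogen on an aromatic ring gives a 36-fold lower number from compound 1 to compound 4 (1.56 log units; beyond the scatter) as the one measured pair for that group. As far as these compounds go, whether a plain benzyl or a longer chain at this place would behave alike stays open. The data offer no explanation for any of these steps.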